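The compounds below may be only part of what the source reports. "The series", "measured", "known", "first", "only" and "open" are said of these compounds alone.

Growth inhibition of a human prostate cancer cell line was followed in a functional assay on DU-145 cells (Homo sapiens) for inhibition, read by trypan blue exclusion, with a stated time of 96 h; on this read-out lower numbers stand for stronger inhibition of growth and higher numbers for weaker inhibition of growth. Compound 1, `Cc1cc(C)cc(/C=C(\C(=O)c2ccc(Br)cc2)S(=O)(=O)Cc2ccc(F)cc2)c1`, gives 10000 nM in this assay. Compound 2, `COc1ccc(/C=C(\C(=O)c2ccc(Br)cc2)S(=O)(=O)Cc2ccc(F)cc2)cc1`, carries 4-methoxyphenyl in place of 3,5-dimethylphenyl on a double-bonded chain carbon bound to a double-bonded chain carbon; in this assay compound 2 gives 25000 nM. That single change brought a 2.5-fold higher number from compound 1 to compound 2 (0.40 log units; beyond the scatter), a weakening of growth inhibition. Compound 3, `Cc1cc(C)cc(/C=C(\C(=O)c2ccc(Cl)cc2)S(=O)(=O)c2ccc(Br)cc2)c1`, rests on a different core, and the difference between the two cores is not broken down here. In this assay compound 3 gives 10000 nM, level with compound 1 within the usual scatter, so no order between those two can be claimed. Compound 4, `COc1ccc(/C=C(\C(=O)c2ccc(Cl)cc2)S(=O)(=O)c2ccc(Br)cc2)cc1`, has not yet been measured. It differs from compound 3 by 4-methoxyphenyl in place of 3,5-dimethylphenyl on a double-bonded chain carbon bound to a double-bonded chain carbon, the same change at the same place as the one made from compound 1 to compound 2, which is the only other time it appears among these compounds. The step is expected to be a 2.5-fold higher number from compound 3 to compound 4 (0.40 log units; beyond the scatter), because the same change once gave a 2.5-fold higher number from compound 1 to compound 2 (0.40 log units; beyond the scatter). With a single example behind it, this expectation is loose. Compound 4 is therefore estimated at 25000 nM, between 12000 nM and 50000 nM.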

Compound 4, concentration for 50% growth inhibition: 10000 nM
Compound 4: the middle estimate sits 2.5-fold (0.40 log units) above what was measured; the whole stated range lies above it.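

In this assay, putting 4-methoxyphenyl in place of 3,5-dimethylphenyl on the second core gave no change at the digits printed from compound 3 to compound 4 (within the scatter). Set beside the earlier result, this step cannot be said to differ from it, so the series gives no firm sign that the core alters the effect of the change: the same change on two cores in this assay, a 2.5-fold higher number (0.40 log units; beyond the scatter) from compound 1 to compound 2 and no change at the digits printed (within the scatter) from compound 3 to compound 4, 2.5-fold (0.40 log units) apart, within the scatter of two such steps. Nor does this prove that the change behaves identically on both cores: with only two pairs, one step beyond the scatter and the other within it, a modest weakening and no effect at all both remain possible on a further core.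

The compounds shown leave open how growth inhibition would respond if an amine or a carboxylic acid stood on this aromatic ring in place of the methoxy or methyl groups. They also leave open whether a longer chain between the ring and the double-bonded chain carbon would change the picture.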